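This account rests on a few compounds, and the source may have more. Where it says the series, first, only, none or still open, it means among the compounds named here.

Of the compounds shown here, two have been measured in a functional assay on a cell-free system (plasma, Homo sapiens), with a stated time of 3 min; a lower number here means a stronger inhibitor, a higher number a weaker inhibitor. Compound 1 `CC1(C[C@@H](O)C(=O)N2N=CC[C@H]2C(=O)NCc2cc(Cl)ccc2-n2cnnn2)CC1` gives 730 nM in this assay. Compound 2 `O=C(NCc1cc(Cl)ccc1-n1cnnn1)[C@@H]1CCON1C(=O)[C@H](O)c1ccccc1` gives 1500 nM in this assay. Compound 1 has the lower of the two numbers, and its gap to compound 2 lies beyond the usual scatter, so compound 1 stands as the stronger inhibitor of the pair. Among the compounds with values here, no two measured compounds differ in a single place, so no step size is yet known from measurement, and the gap between compound 1 and compound 2 cannot be tied to one change.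

Compound 3 `CC(C)(C)C[C@@H](O)C(=O)N1N=CC[C@H]1C(=O)NCc1cc(Cl)ccc1-n1cnnn1` has not been measured. It differs from compound 1 in one place: tert-butyl in place of 1-methylcyclopropyl on a saturated chain carbon, two bonds along the chain from a carbonyl carbon and an oxygen on a saturated carbon. As counted, the group that leaves and the group that enters match in size and in the absence of donors and acceptors, so the change is a small one on the structures alone. The step expected in this assay is a 1.0-fold lower number from compound 1 to compound 3 (0.02 log units; within the scatter), which stays within the scatter; no shift beyond it is foreseen in either direction. For compound 3 the estimate is 700 nM, with a range from 300 nM to 1600 nM.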

Compound 3, half-maximal inhibitory concentration: 590 nM
Compound 3: the middle estimate sits 1.2-fold (0.07 log units) above what was measured; the measured number falls inside the stated range.
By their numbers in this assay, from the lowest: compounds 3 and 1 (each within the scatter of the next); then compound 2.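

In this assay, within the data shown here, tert-butyl in place of 1-methylcyclopropyl on a saturated chain carbon, two bonds along the chain from a carbonyl carbon and an oxygen on a saturated carbon, gives a 1.2-fold lower number from compound 1 to compound 3 (0.09 log units; within the scatter), the first step that can be read from measurement. At this place, the three-membered ring of 1-methylcyclopropyl can thus give way to the ring-free tert-butyl, with the heavy-atom count unchanged, without a shift beyond the scatter, so the two compounds cannot be told apart in this read-out. No measurement at hand bears on why the two groups read alike.

The compounds shown cover only these two closely matched carbon groups at this place, so it remains open how the number responds to an amine, a carboxylic acid or a longer chain such as n-hexyl there. Compound 2 still differs from every other compound shown in more than one place, so its gap to them cannot be tied to any single change.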